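The compounds below may be only part of what the source reports. "The series", "measured", "known", "first", "only" and "open" are said of these compounds alone.

Of the compounds shown here, three have been measured in an assay on HEK293 cells for positive allosteric modulation of metabotropic glutamate receptor 5 (Homo sapiens), read by FLIPR, with a stated time of 1 h; a higher number here means that more compound is needed for the effect, a lower number that less compound is needed. Compound 1 `O=C1NCCc2nc(C#Cc3ccccc3F)sc21` gives 1500 nM in this assay. Compound 2 `O=C(C1CC(F)(F)C1)N1CCc2nc(C#Cc3cccc(F)c3)sc2C1` gives 2.5 nM in this assay. Compound 3 `CC(C)S(=O)(=O)N1Cc2nc(C#Cc3ccccc3)sc2C1` returns > 10000 nM in this assay, which is a limit of the assay and not a number. Compound 3 therefore stands at the upper boundary of the numbers shown, and one of the three values sits there (the limit of > 10000 nM in this assay, at which 1 of the 3 values shown sits). Compound 4 `O=S(=O)(N1CCCCC1)N1Cc2nc(C#Cc3ccccc3)sc2C1` differs from compound 3 in one place: piperidin-1-yl in place of isopropyl on a sulfonyl sulfur. Going by the values given here, no step between two measured compounds covers this change, so the size of the move can only be anticipated, not read from the data. Because compound 3 sits at the limit (the limit of > 10000 nM in this assay, at which 1 of the 3 values shown sits), the expected step of a number no higher from compound 3 to compound 4 (the limit leaves the size open) is no larger than the scatter, with compound 4 likely to remain at the limit as well. Compound 4 is estimated at 10000 nM in this assay, with a range from 3000 nM to 30000 nM.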

Compound 4, half-maximal effective concentration: 250 nM
The estimate for compound 4 lay 40-fold (1.60 log units) above the measured number; measured number below the stated range.
By their numbers in this assay, from the lowest: compound 2; then compound 4; then compound 1. At a limit, above all of these: compound 3.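

Moving from isopropyl to piperidin-1-yl on a sulfonyl sulfur, whose other neighbour is a sulfonamide nitrogen in a ring, gives an at least 40-fold lower number from compound 3 to compound 4 (1.60 log units; beyond the scatter) in this assay. Going by these compounds alone, compounds 1 and 2 carry no sulfonyl group, so only this pair shows that the group on this sulfur can decide whether a compound registers a number in the assay at all. The value of compound 3 is a limit of the assay and not a number, so the step sets only a bound on the change: the limit of > 10000 nM in this assay, at which 1 of the 4 values shown sits.

One step cannot separate the roles of the ring, its size and its nitrogen, and a morpholin-4-yl, a dimethylamino or a cyclohexyl group on the same sulfur would bear on this. On these data alone, how a fluorine on the phenyl ring of compound 4 would act also remains open.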